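A few compounds are considered here, and "the series" means these few. Any claim that something is new, unique, unknown or untested is made for them only; others in the source may bear on it.

Series of three compounds sharing one core, all measured in a functional assay for inhibition of Polyunsaturated fatty acid 5-lipoxygenase (Homo sapiens); on this read-out higher numbers stand for an effect only at larger amounts of compound and lower numbers for an effect already at smaller amounts. Compound 1 `CN(O)C(=O)CCSc1nc2cc(Cl)ccc2s1` gives 20 nM in this assay, and compound 2 `CN(O)C(=O)NCCSc1nc2cc(Cl)ccc2s1` gives 20 nM. Compound 3 `O=C(NO)NCCSc1nc2ccccc2s1` gives 5200 nM in this assay and thus shows the highest number of the three; its gaps to compound 1 and to compound 2 are both beyond the scatter.

The next compound, compound 4 `O=C(NO)NCCSc1nc2cc(Cl)ccc2s1`, is still to be measured. It differs from compound 3 by chloro in place of hydrogen on an aromatic carbon. Within the data shown here, no measured step isolates this change: compound 3 differs from compound 2 in two places at once, the chloro and the methyl on the hydroxyurea nitrogen, so the large gap between compound 3 and compound 2 cannot be assigned to either alone. Among the measured compounds shown here, the one single step in hand, no change at the digits printed from compound 1 to compound 2 (within the scatter), concerns the chain end and not the ring, and so bears on compound 4 only indirectly, by showing that the chain end tolerates variation. The chloro step is therefore estimated to account for part of the gap between compound 3 and compound 2, and the expected step is a 6.5-fold lower number from compound 3 to compound 4 (0.81 log units; beyond the scatter), toward a smaller number. For compound 4 the estimated value in this assay is 800 nM, within a range of 80 nM to 5000 nM.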

Compound 4, half-maximal effective concentration: 24500 nM
The estimate for compound 4 lay 31-fold (1.49 log units) below the measured number; measured number above the stated range.
By their numbers in this assay, from the lowest: compounds 1 and 2 (each within the scatter of the next); then compound 3; then compound 4.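

In this assay, chloro in place of hydrogen on an aromatic carbon gives a 4.7-fold higher number from compound 3 to compound 4 (0.67 log units; beyond the scatter), so on the hydroxyurea without the methyl this change moves the number up, and it does not contribute to closing the gap between compound 3 and compound 2. The nitrogen substituent carries far more weight: hydrogen in place of methyl on the amide-type nitrogen gives a 1200-fold higher number from compound 2 to compound 4 (3.09 log units; beyond the scatter), and the matching exchange of the chain end of compound 1 gives a 1200-fold higher number from compound 1 to compound 4 (3.09 log units; beyond the scatter), so the tolerance of the chain end seen so far extends only to the two compounds that keep this methyl. No measurement in hand accounts for either the chloro step or the methyl step.

From the compounds shown here alone, the chloro step has been read only without the methyl, so its size and direction on the methylated hydroxyurea remain open. Also open, going by these compounds, is how an ethyl on the same nitrogen, or a fluoro or a methoxy in place of the chloro on the same aromatic carbon, would read in this assay.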